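Compound 3 Without the tert-Butoxycarbonyl Group: An Expected Value

This account rests on a few compounds, and the source may have more. Where it says the series, first, only, none or still open, it means among the compounds named here.

Compound 1, `CC(C)=CCC1=C(OCc2cn(-c3ccnc4cc(Cl)ccc34)nn2)C(=O)c2ccccc2C1=O`: 1940000 nM
Compound 2, `CC(C)=CCC1=C(OCc2cn(C3CCN(C(=O)OC(C)(C)C)CC3)nn2)C(=O)c2ccccc2C1=O`: 136000 nM

Of the compounds shown here, two have been measured in an ADME assay on HepG2 cells (Homo sapiens) for cytotoxicity, read by MTT assay, with a stated time of 24 h; on this read-out lower numbers stand for higher toxicity in this test and higher numbers for lower toxicity in this test. Compound 1 gives 1940000 nM there, while compound 2 gives 136000 nM. Among the compounds with values here, of the two numbers, compound 2 stands lowest; its only neighbour, compound 1, gives the higher number, and the gap between them lies beyond the usual scatter of this test. Within the data shown here, no pair of measured compounds differs in a single place, so no step of known size is available.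

Compound 3, `CC(C)=CCC1=C(OCc2cn(C3CCNCC3)nn2)C(=O)c2ccccc2C1=O`, is the untested member. It differs from compound 2 in one change: hydrogen in place of tert-butoxycarbonyl on an amine nitrogen in a ring. Among the measured compounds shown here, nothing among the measured compounds shows what such a change does in this assay, so the expectation rests on compound 2 alone. The step is expected to be modest and could go either way; the writer expects it to stay within or close to the scatter, as a 1.5-fold higher number from compound 2 to compound 3 (0.17 log units; within the scatter). On that basis compound 3 is estimated to give 200000 nM in this assay, with a range from 60000 nM to 700000 nM.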

Compound 3, half-maximal cytotoxic concentration: 570000 nM
The estimate for compound 3 lay 2.9-fold (0.45 log units) below the measured number, and the stated range covers the measured number.
By their numbers in this assay, from the lowest: compound 2; then compound 3; then compound 1.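

The result gives this assay its first step of known size at this site: hydrogen in place of tert-butoxycarbonyl on an amine nitrogen in a ring brings a 4.2-fold higher number from compound 2 to compound 3 (0.62 log units; beyond the scatter) and so moves toward lower toxicity in this test. Compound 3 also connects the two earlier compounds, which differ in more than one place, since piperidin-4-yl in place of 7-chloroquinolin-4-yl on an aromatic nitrogen brings a 3.4-fold lower number from compound 1 to compound 3 (0.53 log units; beyond the scatter) and thus the wide gap between them now resolves into two modest steps, each beyond the scatter. No measurement here explains either step.

The compounds shown leave open whether the rise from removing tert-butoxycarbonyl is particular to that group or would also appear with an acetyl group, a methyl group or a longer alkyl chain on the same ring nitrogen. They also leave open how far the step at the aromatic nitrogen depends on the chlorine of 7-chloroquinolin-4-yl, which the unsubstituted quinolin-4-yl group or a simple phenyl ring in that place would help to settle.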